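Methyl branching next to the amide nitrogen of compound 1

The compounds below may be only part of what the source reports. "The series", "measured", "known", "first", "only" and "open" are said of these compounds alone.

Values in an assay (Canis lupus familiaris) for binding affinity to platelet-activating factor receptor (Homo sapiens), read by radioligand binding; on this read-out lower numbers stand for stronger inhibition and higher numbers for weaker inhibition:
- compound 1 `O=C(/C=C/C=C(c1cccc(F)c1)c1cccc(F)c1)NCCCCc1cccnc1`: 20 nM
- compound 2 `O=C(/C=C\C=C(c1ccccc1)c1ccccc1)NCCCCc1cccnc1`: 400 nM
- compound 3 `COc1ccc(C(=C/C=C/C(=O)NC(C)(C)CCCc2cccnc2)c2ccc(OC)cc2)cc1`: 85 nM

Compound 1 gives the lowest number of the three; compound 3 stands nearest, beyond the scatter, and compound 2 furthest, also beyond the scatter. Among the compounds with values here, neither pair shares a single change with compound 1, so no counted step is available.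

Compound 4 `C[C@H](CCCc1cccnc1)NC(=O)/C=C/C=C(c1cccc(F)c1)c1cccc(F)c1` differs from compound 1 by methyl in place of hydrogen on a saturated chain carbon bound to an amide-type nitrogen and a saturated chain carbon. Within the data shown here, no measured pair shows this change on its own; compound 3 carries two methyls at that carbon together with other changes, so it gives no clean guide.

Expectation: a small step, possibly weakening, likely within the scatter of this assay. Compound 4 is estimated at 30 nM, range 10 nM to 90 nM. The expected step is a 1.5-fold higher number from compound 1 to compound 4 (0.18 log units; within the scatter).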

Compound 4, half-maximal inhibitory concentration: 170 nM
The estimate for compound 4 lay 5.7-fold (0.75 log units) below the measured number; measured number above the stated range.
By their numbers in this assay, from the lowest: compound 1; then compounds 3 and 4 (each within the scatter of the next); then compound 2.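

In this assay, within the data shown here, methyl in place of hydrogen on a saturated chain carbon bound to an amide-type nitrogen and a saturated chain carbon gives an 8.5-fold higher number from compound 1 to compound 4 (0.93 log units; beyond the scatter), the first clean reading at this position. This single added carbon, in the one stereo form carried by compound 4, is enough to weaken inhibition beyond the scatter. The data shown offer no explanation for this loss.

Open, on these data alone, is whether the opposite methyl stereo form would give the same step. Also open, as far as these compounds go, is how an ethyl or hydroxyl group would behave on this carbon.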